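Methoxy Added to a Cinnamamide Core and Cytotoxicity

The compounds below may be only part of what the source reports. "The series", "measured", "known", "first", "only" and "open" are said of these compounds alone.

Four compounds sharing a trimethoxycinnamamide core differ only in the anilide ring. Compound 1 is `COc1cc(/C=C/C(=O)Nc2cc(OC)c(OC)c(OC)c2)cc(OC)c1OC`, compound 2 is `COc1cc(NC(=O)/C=C/c2cc(OC)c(OC)c(OC)c2)cc(OC)c1`, compound 3 is `COc1cc(/C=C/C(=O)Nc2ccccc2)cc(OC)c1OC`, and compound 4, not yet measured, is `COc1ccc(NC(=O)/C=C/c2cc(OC)c(OC)c(OC)c2)cc1`. How the core of compound 3 differs from that of compound 2 is not broken down here.

In a functional assay on HeLa cells (Homo sapiens) for cytotoxicity, read by sulforhodamine B assay, with a stated time of 72 h (a lower number here means a stronger inhibitor, a higher number a weaker inhibitor), compound 2 gives 38900 nM. Compound 1 gives > 50000 nM, which is a limit of the assay rather than a number. Compound 3 gives > 50000 nM, again a limit rather than a number. The change from compound 2 to compound 1 is methoxy in place of hydrogen on an aromatic carbon, and it produced an at least 1.2-fold higher number from compound 2 to compound 1 (0.10 log units; that floor lies within the scatter); that step is only a floor because compound 1 sits at the limit of > 50000 nM in this assay, at which 2 of the 3 values shown sit.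

The change from compound 3 to compound 4 is methoxy in place of hydrogen on an aromatic carbon. It is the same kind of change, but the surroundings differ: for compound 1 the place reads ortho to two methoxy groups and para to a large group, whereas for compound 4 it reads para to a large group alone.

For the measured compounds named here, since compound 3 already sits at a limit and the one comparable step was small, the expected step is a step that the limit leaves unreadable from compound 3 to compound 4. Compound 4 is therefore expected to give about 60000 nM in this assay. For compound 4 the expected range is estimated to run from 20000 nM to 200000 nM, most likely reported only as a limit.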

Compound 4, half-maximal inhibitory concentration: > 50000 nM
Compound 4: no number, only a limit; the forecaster's own chance of this, stated with the estimate: 75%; the middle value lies beyond the limit too.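

The step from compound 3 to compound 4 cannot be read, because both compounds sit at the same limit rather than at a number: the limit of > 50000 nM in this assay, at which 3 of the 4 values shown sit.

The compounds shown leave open how strongly compound 1, compound 3 and compound 4 act in this assay, and so whether changing phenyl to 4-methoxyphenyl shifts the result at all.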